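The source may report more compounds than this note shows. Statements on the series, on what has been measured and on what is new or still open speak of the compounds shown alone.

Working notes on the series. Two compounds share the same core, illustrated by compound 1 `COC(=O)c1ccc(-c2cn(CC(=O)Nc3nc4ccccc4s3)nn2)cc1` and compound 2 `O=C(Cn1cc(-c2ccncc2)nn1)Nc1nc2ccccc2s1`. In a functional assay on BMDM cells (Mus musculus, strain C57BL/6) for inhibition, with a stated time of 2 days (on this read-out lower numbers stand for stronger inhibition and higher numbers for weaker inhibition), compound 1 reaches only the limit of the assay, > 30000 nM, and no number. In this assay compound 2 gives 50 nM. For the measured compounds named here, compound 2 therefore stands as the only numbered value in this assay; the other result is a limit, as set out in the limit of > 30000 nM in this assay, at which 1 of the 2 values shown sits.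

Compound 3 `O=C(Cn1cc(-c2ccc(Cl)cc2)nn1)Nc1nc2ccccc2s1` has not yet been measured. It differs from compound 2 in one place: 4-chlorophenyl in place of pyridin-4-yl on an aromatic carbon.

Going by the values given here, no step between measured compounds is available here, so the size of the change in this assay is judged from the two values alone. Compound 1, which carries a six-membered ring of carbon only at the same position, sits at the limit, (the limit of > 30000 nM in this assay, at which 1 of the 2 values shown sits), while compound 2 carries the pyridin-4-yl and gives a number. For compound 3 the step from compound 2 is expected to weaken inhibition beyond the usual scatter, a 60-fold higher number from compound 2 to compound 3 (1.78 log units; beyond the scatter). Compound 3 is estimated at 3000 nM, with a range from 300 nM to 30000 nM.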

Compound 3, half-maximal inhibitory concentration: 130 nM
For compound 3 the middle estimate is 23-fold (1.36 log units) above the measured one, outside the stated range (below it).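

In this assay, a six-membered ring of carbon only at this position is compatible with strong inhibition: 4-chlorophenyl in place of pyridin-4-yl gives a 2.6-fold higher number from compound 2 to compound 3 (0.41 log units; beyond the scatter), a modest step, so compound 3 keeps a numbered value without the ring nitrogen of pyridin-4-yl. The group carried on that carbon ring separates the two compounds with such a ring, since chloro in place of methoxycarbonyl gives an at least 230-fold lower number from compound 1 to compound 3 (2.36 log units; beyond the scatter), a large step that far exceeds the one between the two rings. Compound 1 remains a limit of the assay, so this large step has a bound and no exact size: the limit of > 30000 nM in this assay, at which 1 of the 3 values shown sits.

The compounds shown leave open whether the result for compound 1 is tied to methoxycarbonyl alone or would also hold for a carboxylic acid or a primary amide on the same ring. They also leave open how pyridin-3-yl, or an unsubstituted phenyl ring, would compare with pyridin-4-yl and 4-chlorophenyl, and so how much of the step to compound 3 belongs to the chloro group and how much to the loss of the ring nitrogen.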